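Swapping the Ester-Bearing Ring for a Methoxypyridine

The compounds below may be only part of what the source reports. "The series", "measured", "known", "first", "only" and "open" are said of these compounds alone.

Of the compounds shown here, three built on one shared core have been tested in a functional assay on MCF7 cells (Homo sapiens) for cytotoxicity, read by sulforhodamine B assay, with a stated time of 72 h; a higher number here means a weaker inhibitor, a lower number a stronger inhibitor. Compound 1 `CCS(=O)(=O)Nc1cc(-c2ccc3ncnc(Nc4ccc(OC)cc4)c3c2)cnc1OC` gives 1790 nM. Compound 2 `CCS(=O)(=O)Nc1cc(-c2ccc3ncnc(Nc4ccc(OC)c(Cl)c4)c3c2)cnc1OC` gives 3320 nM, a change of a 1.9-fold higher number from compound 1 to compound 2 (0.27 log units; within the scatter). Compound 3 `CCS(=O)(=O)Nc1cc(-c2ccc3ncnc(Nc4cccc(C(=O)OC)c4)c3c2)cnc1OC` gives 10100 nM, the highest of the three numbers, making it the weakest inhibitor of the set, since both a 5.6-fold higher number from compound 1 to compound 3 (0.75 log units; beyond the scatter) and a 3.0-fold higher number from compound 2 to compound 3 (0.48 log units; beyond the scatter) lie beyond the scatter.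

Compound 4 `CCS(=O)(=O)Nc1cc(-c2ccc3ncnc(Nc4ccc(OC)nc4)c3c2)cnc1OC` has not yet been measured. It differs from compound 3 by 6-methoxypyridin-3-yl in place of 3-(methoxycarbonyl)phenyl on a nitrogen on an aromatic ring. The entering group carries a methoxy, as does the 4-methoxyphenyl of compound 1, and a 5.6-fold higher number from compound 1 to compound 3 (0.75 log units; beyond the scatter) shows that exchanging that ring for the ester-bearing ring raised the number. The reverse move is therefore expected to lower it, with a 4.0-fold lower number from compound 3 to compound 4 (0.61 log units; beyond the scatter) as the estimated step. This rests on compound 1, whose 1790 nM stands well below compound 3. Among the measured compounds shown here, no measured compound carries a pyridine ring on that nitrogen, so the size of the step is uncertain. Compound 4 is expected to give 2500 nM, within a range from 900 nM to 7000 nM.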

Compound 4, half-maximal inhibitory concentration: 3770 nM
Beside the measured number, compound 4's estimate is 1.5-fold (0.18 log units) below it; low and high end bracket the measured number.
By their numbers in this assay, from the lowest: compounds 1, 2 and 4 (each within the scatter of the next, the first and the last beyond it); then compound 3.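

In this assay the nitrogen on an aromatic ring also accepts a ring with a hetero atom, since 6-methoxypyridin-3-yl in place of 3-(methoxycarbonyl)phenyl gives a 2.7-fold lower number from compound 3 to compound 4 (0.43 log units; beyond the scatter) and so recovers part of what the ester-bearing ring lost. The same group in place of 4-methoxyphenyl gives a 2.1-fold higher number from compound 1 to compound 4 (0.32 log units; beyond the scatter) while in place of 3-chloro-4-methoxyphenyl it gives a 1.1-fold higher number from compound 2 to compound 4 (0.06 log units; within the scatter) and so the pyridine ring and the chlorinated ring cannot be told apart here, although the unchlorinated phenyl ring stays ahead of the pyridine ring by a modest step. Nothing available here explains any of these steps.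

The compounds shown leave open how a carboxylic acid in place of the methyl ester would read at this position. They also leave open what an amine or a longer chain in place of the methoxy on the pyridine ring would do.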